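The source may hold more compounds than are shown below. What is called first, only, known or untested is meant among the compounds shown, and "the series" means these compounds.

Compounds measured so far in a functional assay on HEK293 cells for antagonist activity at metabotropic glutamate receptor 5 (Homo sapiens), read by FLIPR and calcium flux; on this read-out higher numbers stand for weaker inhibition and lower numbers for stronger inhibition:
compound 1 `O=C(N[C@H]1CCC[C@H](NC(=O)c2cnccn2)C1)c1cccc(Cl)c1`, 1370 nM
compound 2 `O=C(NC1CCCC(NC(=O)c2ccccn2)C1)c1cccc(Cl)c1`, 314 nM
compound 3 `O=C(NC1CCCC(NC(=O)c2cccc(Cl)c2)C1)c1cccc(Cl)c1`, 139 nM

Among these three, compound 1 gives the highest number in this assay, and both other compounds lie beyond the scatter below it. Compound 4 `O=C(N[C@H]1CCC[C@H](NC(=O)c2cccc(Cl)c2)C1)c1ccc(F)cc1` has not yet been measured. It differs from compound 1 in one place: 4-fluorophenyl in place of pyrazin-2-yl on a carbonyl carbon.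

Going by the values given here, one measured step bears on this kind of change. The step of a 2.3-fold lower number from compound 2 to compound 3 (0.35 log units; beyond the scatter) swapped a nitrogen-containing ring for a carbon-only ring on a carbonyl carbon, and the number fell modestly. The change from compound 1 to compound 4 is of the same kind, so a lowering of similar size is expected, a 2.5-fold lower number from compound 1 to compound 4 (0.40 log units; beyond the scatter). Compound 4 is therefore estimated at 550 nM, with a range from 200 nM to 1500 nM.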

Compound 4, half-maximal inhibitory concentration: 194 nM
The estimate for compound 4 lay 2.8-fold (0.45 log units) above the measured number, outside the stated range (below it).
By their numbers in this assay, from the lowest: compounds 3, 4 and 2 (each within the scatter of the next, the first and the last beyond it); then compound 1.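

On the read-out of this assay, putting 4-fluorophenyl in place of pyrazin-2-yl on a carbonyl carbon gives a 7.1-fold lower number from compound 1 to compound 4 (0.85 log units; beyond the scatter). Together with a 2.3-fold lower number from compound 2 to compound 3 (0.35 log units; beyond the scatter), this makes two listed pairs in which a carbon-only ring gives the lower number, and no listed pair goes against this. No measurement here explains the drop.

From the compounds shown here alone, it remains open whether the fluorine matters or the loss of the ring nitrogens is enough. A plain phenyl or a 4-methoxyphenyl at this place would help to separate the two.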